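A few compounds are considered here, and "the series" means these few. Any claim that something is new, unique, unknown or untested is made for them only; others in the source may bear on it.

In a toxicity assay on NIH3T3 cells (Mus musculus) for cytotoxicity, read by resazurin assay (a lower number here means that less compound is needed, a higher number that more compound is needed for the effect), compound 2 `COC(=O)c1ccc(NCc2cncn2Cc2ccccc2-c2ccccc2)cc1-c1ccccc1` has no single number, its entry reading "not determined" (no result reported). Compound 1 `COC(=O)c1ccc(NCc2cncn2Cc2cccc(Br)c2)cc1-c1ccccc1` gives > 10000 nM, which is a limit of the assay and not a number. The piece now turns to compound 3 `COC(=O)c1ccc(NCc2cncn2Cc2ccc([N+](=O)[O-])cc2)cc1-c1ccccc1`. The change 4-nitrophenyl in place of 2-phenylphenyl on a saturated chain carbon bound to an aromatic nitrogen puts 4-nitrophenyl in place of 2-phenylphenyl on a saturated chain carbon bound to an aromatic nitrogen. For the measured compounds named here, no measured step bears on this change, so no shift beyond the scatter is expected in this assay, in either direction. That expectation rests only on compound 1, whose reading of > 10000 nM is that same limit. The estimated value for compound 3 is 12000 nM, with an expected range from 4000 nM to 30000 nM.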

Compound 3, half-maximal effective concentration: > 10000 nM
Compound 3: a limit, no number; the forecaster's own chance of this, stated with the estimate: 80%; the middle value lies beyond the limit too.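

No step can be read between compound 1 and compound 3, because both values are limits of the assay and not numbers: the limit of > 10000 nM in this assay, at which 2 of the 3 values shown sit. In this assay the compounds shown leave open how 4-nitrophenyl and 3-bromophenyl compare.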